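The source may hold more compounds than are shown below. What is called first, only, known or untested is meant among the compounds shown, and "the series" means these compounds.

Measured so far in a functional assay on MCF7 cells (Homo sapiens) for cytotoxicity, read by MTT assay, with a stated time of 24 h; on this read-out lower numbers stand for stronger inhibition and higher numbers for weaker inhibition:

compound 1 `Cn1c(-c2ccc(NC(=O)CSc3nc4cc(Cl)ccc4o3)cc2)nc(-c2ccccc2)c1-c1ccccc1` — 21.7 ug/mL
compound 2 `Cn1c(-c2ccc(NC(=O)CSc3nc4ccccc4s3)cc2)nc(-c2ccccc2)c1-c1ccccc1` — 15.8 ug/mL
compound 3 `Cn1nnnc1SCC(=O)Nc1ccc(-c2nc(-c3ccccc3)c(-c3ccccc3)n2C)cc1` — 4.5 ug/mL

Compound 3 holds the lowest number of the three. Both steps leading to it, a 4.8-fold lower number from compound 1 to compound 3 (0.68 log units; beyond the scatter) and a 3.5-fold lower number from compound 2 to compound 3 (0.55 log units; beyond the scatter), lie beyond the scatter, whereas a 1.4-fold lower number from compound 1 to compound 2 (0.14 log units; within the scatter) does not; so the two bicyclic groups on the sulfur are not separable from each other, while the 1-methyl-1H-tetrazol-5-yl group stands apart from both.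

Compound 4 `CN1CCN(CC(=O)Nc2ccc(-c3nc(-c4ccccc4)c(-c4ccccc4)n3C)cc2)CC1` is not yet measured. It differs from compound 3 as follows: 4-methylpiperazin-1-yl in place of (1-methyl-1H-tetrazol-5-yl)sulfanyl on a saturated chain carbon bound to a carbonyl carbon. None of the three measured steps bears directly on this change: each of them kept the sulfanyl linkage and swapped only the ring on the sulfur, and none brought in a six-membered non-aromatic ring. What the measured steps do show is that the move from the bicyclic groups to the smaller five-membered aromatic ring gave the lowest number, compound 3. Removing the sulfanyl group altogether is a step of a different kind, and the direction cannot be read from compounds 1, 2 and 3. A modest loss relative to compound 3 is therefore assumed, with wide uncertainty. Compound 4 is expected to give 9 ug/mL in this assay, within a range from 3 ug/mL to 27 ug/mL. This estimate corresponds to an expected step of a 2.0-fold higher number from compound 3 to compound 4 (0.30 log units; within the scatter).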

Compound 4, half-maximal inhibitory concentration: 76.5 ug/mL
Estimate against measurement, compound 4: 8.5-fold (0.93 log units) below, and the stated range ends below it.
By their numbers in this assay, from the lowest: compound 3; then compounds 2 and 1 (each within the scatter of the next); then compound 4.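

In this assay, the 4-methylpiperazin-1-yl group on the saturated chain carbon bound to a carbonyl carbon gives the largest step in the series (a 17-fold higher number from compound 3 to compound 4 (1.23 log units; beyond the scatter)), and it also separates from both bicyclic sulfanyl groups (a 4.8-fold higher number from compound 2 to compound 4 (0.69 log units; beyond the scatter); a 3.5-fold higher number from compound 1 to compound 4 (0.55 log units; beyond the scatter)). This position therefore responds to more than the choice of ring on the sulfur: all three sulfanyl compounds hold lower numbers than compound 4, with none of the four going against this. The leaving and entering groups match in heavy-atom count, so that count does not separate them, and no measurement available here explains the loss.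

The compounds shown leave open whether the difference follows the loss of the sulfur linkage, the loss of the aromatic ring or the change in ring hetero atoms, since all of these change together in this one step. A tetrazole ring joined directly through nitrogen, or a morpholin-4-yl or piperidin-1-yl group on the same chain carbon, would help to separate these changes.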